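The source may hold more compounds than are shown below. What is called first, only, known or untested is meant among the compounds shown, and "the series" means these compounds.

Working notes on the series. Both measured compounds share one core; compound 1 `COCCOc1nn(C)c2ncnc(NS(=O)(=O)c3cccc(Cl)c3Cl)c12` carries a methoxyethoxy group and a methyl on ring nitrogen, while compound 2 `CNC(=O)Cn1nc(OC)c2c(NS(=O)(=O)c3cccc(Cl)c3Cl)ncnc21` carries a methoxy group and a (methylcarbamoyl)methyl group. In a functional assay on cells for antagonist activity at C-C chemokine receptor type 4 (Homo sapiens), read by GTPgammaS binding (a higher number here means a weaker inhibitor, a lower number a stronger inhibitor), compound 1 gives 794 nM. In this assay compound 2 gives 631 nM. Compound 2 has the lower of the two numbers, but the gap to compound 1 is within the scatter, so the pair cannot be told apart on this evidence.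

Compound 3 `COc1nn(CC(=O)O)c2ncnc(NS(=O)(=O)c3cccc(Cl)c3Cl)c12` differs from compound 2 by one change: hydroxy in place of methylamino on a carbonyl carbon. Among the measured compounds shown here, no measured pair shows this change, so its effect is unknown from the data. A modest step towards a higher number, of a size beyond the scatter, is expected for compound 3, though no change at all is within the range held open. Compound 3 is estimated at 1200 nM, with a range of 350 nM to 4000 nM, the expected step being a 1.9-fold higher number from compound 2 to compound 3 (0.28 log units; within the scatter).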

Compound 3, half-maximal inhibitory concentration: 200 nM
The estimate for compound 3 lay 6.0-fold (0.78 log units) above the measured number; the measured number lies below the stated range.
By their numbers in this assay, from the lowest: compound 3; then compounds 2 and 1 (each within the scatter of the next).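

At the carbonyl carbon of the side chain, the change from methylamino to hydroxy, which turns methylcarbamoyl into carboxy, has a readable effect: in this assay it gives a 3.2-fold lower number from compound 2 to compound 3 (0.50 log units; beyond the scatter). Among the compounds shown here, this is the first step that can be read, and it shows that this position responds to the group on the carbonyl carbon, with the free carboxy form on the side of the lower number. For the compounds shown here, nothing measured so far offers an explanation for this step.

On these data alone, this rests on a single pair, so the roles of the carbonyl substituent and of the chain length stay open. Still untested here are a primary amide, a methyl ester and a longer chain ending in carboxy, as is whether the step carries over to a compound with methoxyethoxy in place of methoxy.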